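This account rests on a few compounds, and the source may have more. Where it says the series, first, only, none or still open, it means among the compounds named here.

Of the compounds shown here, three built on one shared core have been measured in a functional assay on MCF7 cells (Homo sapiens) for antiproliferative activity; on this read-out higher numbers stand for weaker inhibition and lower numbers for stronger inhibition. Compound 1 `CC[C@H](C)Cn1c(Cc2cc(OC)c(OC)c(OC)c2)nc2c(N)nc(F)nc21` gives 43700 nM, compound 2 `C#CCCn1c(Cc2cc(OC)c(OC)c(OC)c2)nc2c(N)nc(F)nc21` gives 25100 nM, and compound 3 `COc1cc(Cc2nc3c(N)nc(F)nc3n2CC2CCC2)cc(OC)c1OC` gives 40700 nM. Compound 3 stands second highest of the three numbers, nearest to compound 1 and furthest from compound 2, though both gaps are within the scatter. The step to compound 4 `CCCCn1c(Cc2cc(OC)c(OC)c(OC)c2)nc2c(N)nc(F)nc21` is propyl in place of cyclobutyl on a saturated chain carbon bound to an aromatic nitrogen. The measured steps that bear on it all exchange the group on that same carbon: a 1.1-fold lower number from compound 1 to compound 3 (0.03 log units; within the scatter), a 1.7-fold lower number from compound 1 to compound 2 (0.24 log units; within the scatter) and a 1.6-fold higher number from compound 2 to compound 3 (0.21 log units; within the scatter), each within the scatter. Across these exchanges no number in this assay has moved beyond the scatter, so no step beyond the scatter is expected for the exchange to propyl either. For compound 4 a value of about 36000 nM is therefore estimated, expected to fall between 15000 nM and 85000 nM. The expected step, a 1.1-fold lower number from compound 3 to compound 4 (0.05 log units; within the scatter), is estimated to remain within the scatter.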

Compound 4, half-maximal inhibitory concentration: 24000 nM
Beside the measured number, compound 4's estimate is 1.5-fold (0.18 log units) above it; the range from low to high includes it.
By their numbers in this assay, from the lowest: compounds 4, 2, 3 and 1 (each within the scatter of the next).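

In this assay, the butyl chain of compound 4 adds a case with neither ring, branch nor triple bond at this position, and propyl in place of cyclobutyl gives a 1.7-fold lower number from compound 3 to compound 4 (0.23 log units; within the scatter). Hydrogen in place of the branching methyl gives a 1.8-fold lower number from compound 1 to compound 4 (0.26 log units; within the scatter), and ethyl in place of ethynyl gives a 1.0-fold lower number from compound 2 to compound 4 (0.02 log units; within the scatter), so among these four compounds none of the three features has moved the number beyond the scatter. No evidence is at hand that bears on these numbers. From the compounds shown here alone, all four groups on this carbon consist of carbon and hydrogen only, so it remains open whether an amine, a carboxylic acid or a longer chain there would move the number beyond the scatter. Going by these compounds, it is also open whether replacing the methoxy groups elsewhere on the shared core would do so.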